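Hydroxypiperidine in Place of Dimethylpiperidine on the Pyridine Core

The compounds below may be only part of what the source reports. "The series", "measured", "known", "first", "only" and "open" are said of these compounds alone.

Of the compounds shown here, three sharing one core have been measured in a functional assay on CHO-K1 cells for antagonist activity at transient receptor potential cation channel subfamily V member 1 (Homo sapiens), read by FLIPR; on this read-out lower numbers stand for stronger inhibition and higher numbers for weaker inhibition. Compound 1 `CC(C(=O)NCc1ccc(C(F)(F)F)nc1Nc1ccccc1)c1ccc(NS(C)(=O)=O)c(F)c1` gives 1400 nM, compound 2 `CC(C(=O)NCc1ccc(C(F)(F)F)nc1N1CCCC1)c1ccc(NS(C)(=O)=O)c(F)c1` gives 211 nM, and compound 3 `CC(C(=O)NCc1ccc(C(F)(F)F)nc1N1CCC(C)(C)CC1)c1ccc(NS(C)(=O)=O)c(F)c1` gives 8 nM. Compound 3 stands at the lowest number of the three: the step of a 26-fold lower number from compound 2 to compound 3 (1.42 log units; beyond the scatter) and the step of a 180-fold lower number from compound 1 to compound 3 (2.24 log units; beyond the scatter) are both beyond the scatter, so compound 3 is the strongest inhibitor among the measured set.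

Going by the values given here, compound 4 `CC(C(=O)NCc1ccc(C(F)(F)F)nc1N1CCC(O)CC1)c1ccc(NS(C)(=O)=O)c(F)c1` differs from compound 3 at the same aromatic carbon that the earlier steps varied: 4-hydroxypiperidin-1-yl in place of 4,4-dimethylpiperidin-1-yl on an aromatic carbon. The step of a 6.6-fold lower number from compound 1 to compound 2 (0.82 log units; beyond the scatter) and the step of a 26-fold lower number from compound 2 to compound 3 (1.42 log units; beyond the scatter) show that this position tolerates large swings, with the saturated six-membered ring bearing two methyl groups giving the lowest number. Replacing that ring with one carrying a hydroxyl is expected to move the number upward in this assay, by a step of about a 7.5-fold higher number from compound 3 to compound 4 (0.88 log units; beyond the scatter), though the direction rests on only these three compounds. Compound 4 is therefore estimated at 60 nM, with a range from 15 nM to 300 nM.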

Compound 4, half-maximal inhibitory concentration: "not active" (no number reported)
No number was reported for compound 4; there is nothing to compare the estimate with.
By their numbers in this assay, from the lowest: compound 3; then compound 2; then compound 1.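

Going by these compounds alone, compound 4 is recorded as "not active" in this assay with no number, so no step from compound 3 to compound 4 can be read. The compounds shown leave open how far compound 4 lies from compound 3, and no available evidence bears on this result.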